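Changing the aryl group on the amide carbonyl

The source may report more compounds than this note shows. Statements on the series, on what has been measured and on what is new or still open speak of the compounds shown alone.

Compound 1 `O=C(NCc1ccc(CNS(=O)(=O)c2ccccc2)cc1)c1ccccc1Cl` — an assay on MDA-MB-231 cells for binding affinity to C-X-C chemokine receptor type 4 (Homo sapiens), read by immunofluorescence and microscopy, with stated times of 10 min and 30 min; a higher number here means that more compound is needed for the effect, a lower number that less compound is needed: 10 nM
Compound 2 `O=C(NCc1ccc(CNS(=O)(=O)c2ccccc2)cc1)c1ccncc1` — this assay: 10 nM

Compound 2 stands level with compound 1: the step of no change at the digits printed from compound 1 to compound 2 (within the scatter) lies within the scatter, so swapping one aromatic ring for another on the carbonyl carbon left the measurement unchanged. Compound 3 `O=C(NCc1ccc(CNS(=O)(=O)c2ccccc2)cc1)c1ccc(Cl)cc1` differs from compound 2 by 4-chlorophenyl in place of pyridin-4-yl on a carbonyl carbon. Among the measured compounds shown here, the one measured step bearing on this change, a ring swap at the same carbonyl carbon, produced no change, so no movement beyond the scatter is expected; the step is estimated as no change at the digits printed from compound 2 to compound 3 (within the scatter). Compound 3 is therefore expected at 10 nM, within a range from 4 nM to 30 nM.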

Compound 3, effective concentration (reported as EC, without a stated level of effect): 100 nM
Compound 3: the middle estimate sits 10-fold (1.00 log units) below what was measured; measured number outside the range, above it.
By their numbers in this assay, from the lowest: compounds 1 and 2 (each within the scatter of the next); then compound 3.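

The aryl group on this carbonyl carbon is not freely interchangeable in this assay after all. 4-chlorophenyl in place of pyridin-4-yl brings a 10-fold higher number from compound 2 to compound 3 (1.00 log units; beyond the scatter) and 4-chlorophenyl in place of 2-chlorophenyl brings a 10-fold higher number from compound 1 to compound 3 (1.00 log units; beyond the scatter) even though both rings carry one chlorine. So where the chlorine sits on the ring counts here, not just its presence.

On these data alone, it remains open how a plain phenyl ring, or a ring carrying an amine or a carboxylic acid, would compare at this carbonyl carbon. Nothing at hand explains the loss seen with 4-chlorophenyl.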